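Furan for Phenyl on a Scaffold Stuck at the Limit

The source may hold more compounds than are shown below. What is called first, only, known or untested is meant among the compounds shown, and "the series" means these compounds.

In a functional assay on CHO cells for antagonist activity at adenosine receptor A2b (Homo sapiens), read by cAMP accumulation, with a stated time of 10 min (on this read-out lower numbers stand for stronger inhibition and higher numbers for weaker inhibition), compound 2 `N#Cc1cccc(-c2nc(N)c3nc(-c4ccccc4)sc3n2)c1` gives only a limit, > 30000 nM. Compound 1 `Nc1nc(-c2ccccc2)nc2sc(-c3ccccc3)nc12` also gives only a limit, > 30000 nM. Compound 3 `Nc1nc(-c2ccco2)nc2sc(-c3ccccc3)nc12` likewise gives only a limit, > 30000 nM. Every value here sits at the limit of > 30000 nM in this assay, at which 3 of the 3 values shown sit, so the steps a step that the two limits leave unreadable from compound 1 to compound 2, a step that the two limits leave unreadable from compound 1 to compound 3 and a step that the two limits leave unreadable from compound 2 to compound 3 cannot be sized. Compound 4 `N#Cc1cccc(-c2nc(N)c3nc(-c4ccco4)sc3n2)c1` differs from compound 2 by furan-2-yl in place of phenyl on an aromatic carbon, the same kind of exchange as in the step that the two limits leave unreadable from compound 1 to compound 3, whose size is equally unreadable. Among the compounds with values here, no measured step therefore gives a direction. The step expected for a number no higher from compound 2 to compound 4 (the limit leaves the size open) is none that can be read. Compound 4 is estimated to stay at the limit, around 30000 nM, with a range from 10000 nM to 100000 nM.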

Compound 4, half-maximal inhibitory concentration: > 30000 nM
Compound 4 was reported as a limit (the forecaster's own chance of this, stated with the estimate: 85%); the middle value sits exactly at the limit.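

Compound 2 and compound 4 are both reported only as limits, so the step between them cannot be read: the limit of > 30000 nM in this assay, at which 4 of the 4 values shown sit.

The compounds shown leave open the size and direction of the furan-2-yl for phenyl exchange in this assay.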